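This account rests on a few compounds, and the source may have more. Where it says the series, first, only, none or still open, it means among the compounds named here.

Working notes on the series, measured in a functional assay on L1210 cells (Mus musculus) for inhibition, with a stated time of 48 h; a lower number here means a stronger inhibitor, a higher number a weaker inhibitor:

- compound 1 `CCNCCCNCCCNCC`: > 100000 nM (limit)
- compound 2 `CCCNCCCNCCCN`: > 100000 nM (limit)
- compound 3 `CNCCCCNCCCNC`: > 100000 nM (limit)

Compound 1 gives only > 100000 nM, which is a limit of the assay and not a number. The series as a whole shows (the limit of > 100000 nM in this assay, at which 3 of the 3 values shown sit). For the measured compounds named here, neither compound 2 nor compound 3 therefore offers a numerical point of comparison, and no step between measured compounds that differ in one place is available.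

The unmeasured compound 4 `CCNCCCCNCCCNCC` departs from compound 1 as follows: (ethylamino)methyl in place of ethylamino on a saturated chain carbon, three bonds along the chain from an amine nitrogen. In words, this is (ethylamino)methyl in place of ethylamino on a saturated chain carbon, three bonds along the chain from an amine nitrogen.

In this assay, no change beyond the scatter is expected, and no direction is favoured, since the expectation rests only on (the limit of > 100000 nM in this assay, at which 3 of the 3 values shown sit). The estimated step is a number no higher from compound 1 to compound 4 (the limit leaves the size open). A further reading at the limit is the likeliest outcome. For compound 4 the expected value is 100000 nM, with an estimated range of 30000 nM to 150000 nM.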

Compound 4, half-maximal inhibitory concentration: 100000 nM
Compound 4: the middle estimate sits on the measured number at the digits printed, within the range that was stated.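

In this assay, (ethylamino)methyl in place of ethylamino on a saturated chain carbon, three bonds along the chain from an amine nitrogen, gives a number no higher from compound 1 to compound 4 (the limit leaves the size open). For the compounds shown here, compound 4 gives 100000 nM, the only reading written as a plain number. No gain in inhibition can be read from this change at this position, and the series stays at the top of the range: the limit of > 100000 nM in this assay, at which 3 of the 4 values shown sit.

From the compounds shown here alone, whether a benzyl group on the terminal nitrogen, or a longer chain at this position, would bring a value clearly lower in this assay stays open. With no reading well inside the range, the compounds shown give no measure of how strongly this position affects inhibition.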